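The compounds below may be only part of what the source reports. "The series", "measured", "known", "first", "only" and "open" are said of these compounds alone.

Compound 1, `CCn1c(C(=O)N[C@@H](C)C(=O)OC)ccc1C(CC)(CC)c1ccc(OCS(=O)(=O)c2ccccc2)c(C)c1`, and compound 2, `CCn1c(C(=O)NCCO)ccc1C(CC)(CC)c1ccc(OCS(=O)(=O)c2ccccc2)c(C)c1`, share a core and differ only in the group on the amide-type nitrogen. In a functional assay on BXPC-3 cells (Homo sapiens) for antiproliferative activity, read by MTT assay, with a stated time of 24 h (on this read-out higher numbers stand for weaker inhibition and lower numbers for stronger inhibition), compound 1 gives 17900 nM, and in this assay compound 2 gives 19900 nM. The two numbers lie within the scatter of each other, so compound 2 stands on a par with compound 1, and the step of a 1.1-fold higher number from compound 1 to compound 2 (0.05 log units; within the scatter) changes nothing that can be read as a real shift. Compound 3, `CCn1c(C(=O)N[C@@H](CO)C(C)C)ccc1C(CC)(CC)c1ccc(OCS(=O)(=O)c2ccccc2)c(C)c1`, again alters the same amide substituent: isopropyl in place of hydrogen on a saturated chain carbon bound to an amide-type nitrogen and a saturated chain carbon. Among the measured compounds shown here, the one measured step that touches this position, a 1.1-fold higher number from compound 1 to compound 2 (0.05 log units; within the scatter), showed that a change of the substituent on the amide-type nitrogen from 1-(methoxycarbonyl)ethyl to 2-hydroxyethyl left this assay unmoved. On that basis the entry of isopropyl in place of hydrogen on the saturated chain carbon bound to the amide-type nitrogen is expected to give no step beyond the scatter, with a 1.0-fold higher number from compound 2 to compound 3 (0.00 log units; within the scatter) as the expected change. Compound 3 is therefore estimated at 20000 nM in this assay, within a range from 8000 nM to 50000 nM.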

Compound 3, half-maximal inhibitory concentration: 13200 nM
Compound 3: middle estimate off by 1.5-fold (0.18 log units), on the high side; the measured number falls inside the stated range.
By their numbers in this assay, from the lowest: compounds 3, 1 and 2 (each within the scatter of the next).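

Among the compounds shown here, with compound 3, the position on the amide-type nitrogen is tested for the first time with added bulk on the chain: isopropyl on a saturated chain carbon bound to an amide-type nitrogen and a saturated chain carbon gives, in this assay, a 1.5-fold lower number from compound 2 to compound 3 (0.18 log units; within the scatter). The exchange of 1-(methoxycarbonyl)ethyl for 1-(hydroxymethyl)-2-methylpropyl on the amide-type nitrogen gives a 1.4-fold lower number from compound 1 to compound 3 (0.13 log units; within the scatter), so the three substituents shown stand on a par here, and the entry of isopropyl, which the earlier pair did not cover, brings no step beyond the scatter. Nothing at hand gives a measured property or any other finding that bears on this result.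

The compounds shown all carry a neutral chain with a hydroxyl or ester group on the amide-type nitrogen, so it remains open whether an amine, a carboxylic acid or a longer chain with a phenyl ring at this position would give a step beyond the scatter. Also open, on these data alone, is whether any change at this position could move the numbers in this assay at all, or whether other parts of the shared core govern them.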